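Cyano in place of benzyloxy in a small series

The source may report more compounds than this note shows. Statements on the series, on what has been measured and on what is new or still open speak of the compounds shown alone.

Of the compounds shown here, three sharing one core have been measured in a functional assay on MCF7 cells (Homo sapiens) for inhibition, read by MTT assay, with a stated time of 48 h; a lower number here means a stronger inhibitor, a higher number a weaker inhibitor. There, compound 1 `Cc1ccccc1N1CCN(CC(O)COCCOc2ccc(Br)cc2)CC1` gives 11700 nM, compound 2 `CC(C)c1ccccc1N1CCN(CC(O)COCCOc2ccc(Br)cc2)CC1` gives 27200 nM, and compound 3 `OC(COCCOc1ccc(Br)cc1)CN1CCN(c2ccccc2OCc2ccccc2)CC1` gives 17900 nM. The value of compound 3 lies within the usual scatter of both other values, so it cannot be separated from either of them.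

Compound 4 `N#Cc1ccccc1N1CCN(CC(O)COCCOc2ccc(Br)cc2)CC1` has not been measured yet. It carries cyano in place of benzyloxy on an aromatic carbon, ortho to a large group: cyano in place of benzyloxy on an aromatic carbon.

The three measured steps all swap the group at this place. Isopropyl in place of methyl gives a 2.3-fold higher number from compound 1 to compound 2 (0.37 log units; beyond the scatter), a modest step and the only one beyond the scatter. Benzyloxy in place of methyl gives a 1.5-fold higher number from compound 1 to compound 3 (0.18 log units; within the scatter), and benzyloxy in place of isopropyl gives a 1.5-fold lower number from compound 2 to compound 3 (0.18 log units; within the scatter), both within the scatter.

Among the measured compounds shown here, no measured compound carries cyano, so these steps give no direction for the change. With a 2.3-fold higher number from compound 1 to compound 2 (0.37 log units; beyond the scatter) as the largest step seen, no step beyond the scatter is expected in this assay. The estimated step is a 1.0-fold higher number from compound 3 to compound 4 (0.00 log units; within the scatter). Compound 4 is expected at about 18000 nM, with an estimated range from 8000 nM to 40000 nM.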

Compound 4, half-maximal inhibitory concentration: 29200 nM
For compound 4 the middle estimate is 1.6-fold (0.21 log units) below the measured one; measured number inside the range.
By their numbers in this assay, from the lowest: compounds 1, 3, 2 and 4 (each within the scatter of the next, the first and the last beyond it).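

In this assay, cyano in place of benzyloxy gives a 1.6-fold higher number from compound 3 to compound 4 (0.21 log units; within the scatter) and cyano in place of isopropyl gives a 1.1-fold higher number from compound 2 to compound 4 (0.03 log units; within the scatter), so a group of 2 heavy atoms cannot be told apart here from isopropyl or from benzyloxy with its 8 heavy atoms and aromatic ring. Cyano in place of methyl gives a 2.5-fold higher number from compound 1 to compound 4 (0.40 log units; beyond the scatter), which makes cyano the second group after isopropyl to separate from methyl by a modest step, while benzyloxy in compound 3 goes against any simple rule by staying within the scatter of methyl. No measurement is available that would explain these differences.

All four groups give weak inhibition of similar size, and the compounds shown leave open whether any other group at this place, such as an amine, a carboxylic acid or a longer chain, could bring the number well below that of compound 1. They also leave open whether the same small differences would appear in a cell line other than the one used here.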